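Swapping Chlorines for Methoxy Groups on a Benzylamine Arm

A few compounds are considered here, and "the series" means these few. Any claim that something is new, unique, unknown or untested is made for them only; others in the source may bear on it.

Compound 1, `Nc1cc(N)c2nc(-c3ccccc3)c(NCc3ccc(Cl)c(Cl)c3)nc2c1`, gives 34700 nM in a functional assay on SK-MEL-5 cells (Homo sapiens) for inhibition, read by sulforhodamine B assay, with a stated time of 48 h; a lower number here means that less compound is tolerated, a higher number that more compound is tolerated.
Compound 2, `CCOC(=O)[C@H](CCC(=O)O)NC(=O)c1ccc(Sc2nc3cc(N)cc(N)c3nc2-c2ccccc2)cc1`, gives 85100 nM in this assay.
Compound 3, `CCOC(=O)[C@H](CCC(=O)O)NC(=O)c1ccc(Oc2nc3cc(N)cc(N)c3nc2-c2ccccc2)cc1`, gives < 100000 nM in this assay, and that value is a limit of the assay rather than a number.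

Of the two compounds that returned a number, compound 1 stands lowest; compound 2 gives a higher number, and the gap between them lies beyond the usual scatter of this assay. For compound 3 only a limit is known: the limit of < 100000 nM in this assay, at which 1 of the 3 values shown sits.

Compound 4, `COc1ccc(CNc2nc3cc(N)cc(N)c3nc2-c2ccccc2)cc1OC`, differs from compound 1 in a single place: 3,4-dimethoxyphenyl in place of 3,4-dichlorophenyl on a saturated chain carbon bound to a nitrogen on an aromatic ring. The shared core of compound 1 and the rest of the molecule are unchanged. Within the data shown here, no pair of measured compounds shows this same exchange, so there is no measured step to lean on, and the direction of the change is open.

Compound 4 is expected to give a number close to that of compound 1, with a modest shift toward a higher number being as plausible as none at all. The estimate for compound 4 is 45000 nM, with a range from 15000 nM to 100000 nM. This estimate corresponds to an expected step of a 1.3-fold higher number from compound 1 to compound 4 (0.11 log units; within the scatter), judged to lie within or only just beyond the scatter.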

Compound 4, concentration lethal to 50% of the cells: 77600 nM
For compound 4 the middle estimate is 1.7-fold (0.24 log units) below the measured one, within the range that was stated.
By their numbers in this assay, from the lowest: compound 1; then compounds 4 and 2 (each within the scatter of the next).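

This exchange is the only one-place change among the compounds shown, so it gives the first direct reading of this position. Putting 3,4-dimethoxyphenyl in place of 3,4-dichlorophenyl on a saturated chain carbon bound to a nitrogen on an aromatic ring gives a 2.2-fold higher number from compound 1 to compound 4 (0.35 log units; beyond the scatter) in this assay, a modest step showing that the group at this position can shift the number even though the shared core stays the same. The entering group brings hydrogen-bond acceptors and the leaving group has none, but a single pair cannot link the step to that difference or to the loss of chlorine, and nothing measured here gives a cause for it.

A single exchange also leaves open whether the two substituents on this ring contribute equally or one accounts for most of the step. Other groups in place of 3,4-dimethoxyphenyl, such as a phenyl ring carrying a nitrile or a trifluoromethyl group, could show whether this higher number holds beyond compound 4, and so could a longer chain carrying the same ring.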